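Moving the methyl on the aniline ring of compound 3

The compounds below may be only part of what the source reports. "The series", "measured", "known", "first", "only" and "open" are said of these compounds alone.

Three compounds share one core and differ only in the aryl group on the nitrogen. Compound 1 `COc1ccc(Nc2nc(SCc3cn(Cc4ccccc4Cl)nn3)nc(-c3ccccc3)c2C#N)cc1` gives 8050 nM in a functional assay on MCF7 cells (Homo sapiens) for inhibition, read by MTT assay, with a stated time of 72 h; a lower number here means a stronger inhibitor, a higher number a weaker inhibitor. Compound 2 `N#Cc1c(Nc2cccc(C(F)(F)F)c2)nc(SCc2cn(Cc3ccccc3Cl)nn2)nc1-c1ccccc1` gives 12600 nM, and compound 3 `Cc1cccc(Nc2nc(SCc3cn(Cc4ccccc4Cl)nn3)nc(-c3ccccc3)c2C#N)c1` gives 19600 nM, the highest number of the three; a 2.4-fold higher number from compound 1 to compound 3 (0.39 log units; beyond the scatter), while a 1.6-fold higher number from compound 2 to compound 3 (0.19 log units; within the scatter). Compound 4 `Cc1ccccc1Nc1nc(SCc2cn(Cc3ccccc3Cl)nn2)nc(-c2ccccc2)c1C#N` is not yet measured; the change is 2-methylphenyl in place of 3-methylphenyl on a nitrogen on an aromatic ring. The measured steps at this same position were small, and none bears directly on shifting the methyl. The expected step of a 1.1-fold lower number from compound 3 to compound 4 (0.04 log units; within the scatter) is therefore none beyond the scatter. Compound 4 is estimated at 18000 nM, with a range from 7000 nM to 45000 nM.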

Compound 4, half-maximal inhibitory concentration: 7950 nM
Compound 4: middle estimate off by 2.3-fold (0.35 log units), on the high side; measured number inside the range.
By their numbers in this assay, from the lowest: compounds 4, 1, 2 and 3 (each within the scatter of the next, the first and the last beyond it).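

Moving the methyl alone, with the same atoms joined differently, gives a real change in this assay: a 2.5-fold lower number from compound 3 to compound 4 (0.39 log units; beyond the scatter). So where the methyl sits on this ring matters, not only which group is present. The other two steps stay small: a 1.6-fold lower number from compound 2 to compound 4 (0.20 log units; within the scatter), and a 1.0-fold lower number from compound 1 to compound 4 (0.01 log units; within the scatter). Nothing available explains the shift.

As far as these compounds go, how 4-methylphenyl or 2-ethylphenyl on this nitrogen would compare with compound 4 remains open.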